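Shortening the chain: from compound 3 to compound 4

A few compounds are considered here, and "the series" means these few. Any claim that something is new, unique, unknown or untested is made for them only; others in the source may bear on it.

In a functional assay on RAW264.7 cells (Mus musculus) for inhibition, read by Griess assay, with stated times of 1 h and 24 h (a higher number here means a weaker inhibitor, a lower number a stronger inhibitor), compound 1 (`CCCOc1ccccc1C1CC(=O)c2ccccc2O1`) gives 46000 nM and compound 2 (`CC(C)COc1ccccc1C1CC(=O)c2ccccc2O1`) gives 36700 nM on the same read-out. Compound 3 (`CCCCCOc1ccccc1C1CC(=O)c2ccccc2O1`) gives 39200 nM and stands within the scatter of both other compounds. Compound 4 (`CCCCOc1ccccc1C1CC(=O)c2ccccc2O1`) differs from compound 3 by hydrogen in place of methyl on a saturated chain carbon, four bonds along the chain from an oxygen on an aromatic ring in one place: hydrogen in place of methyl on a saturated chain carbon, four bonds along the chain from an oxygen on an aromatic ring. The measured chain steps are a 1.3-fold lower number from compound 1 to compound 2 (0.10 log units; within the scatter) and a 1.2-fold lower number from compound 1 to compound 3 (0.07 log units; within the scatter) and a 1.1-fold higher number from compound 2 to compound 3 (0.03 log units; within the scatter) and all lie within the scatter. The expected step, a 1.0-fold higher number from compound 3 to compound 4 (0.01 log units; within the scatter) in this assay as estimated, is therefore none beyond the scatter. The estimate for compound 4 is 40000 nM with 25000 nM to 64000 nM as its expected range.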

Compound 4, half-maximal inhibitory concentration: 48700 nM
For compound 4 the middle estimate is 1.2-fold (0.09 log units) below the measured one, and the stated range covers the measured number.
By their numbers in this assay, from the lowest: compounds 2, 3, 1 and 4 (each within the scatter of the next).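

In this assay, hydrogen in place of methyl on a saturated chain carbon, four bonds along the chain from an oxygen on an aromatic ring, is tolerated: a 1.2-fold higher number from compound 3 to compound 4 (0.09 log units; within the scatter). The other two new comparisons also stay flat, with a 1.3-fold higher number from compound 2 to compound 4 (0.12 log units; within the scatter) and a 1.1-fold higher number from compound 1 to compound 4 (0.02 log units; within the scatter). This change now has a second matched pair, and the two agree: the same change on two cores in this assay, a 1.3-fold lower number (0.10 log units; within the scatter) from compound 1 to compound 2 and a 1.2-fold lower number (0.09 log units; within the scatter) from compound 4 to compound 3, 1.0-fold (0.00 log units) apart, within the scatter of two such steps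

On these data alone, whether an amine, a carboxylic acid or a longer chain in place of this methyl would move the number beyond the scatter remains open.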